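Substituting the Ring Nitrogen of an Isatin-type Anticancer Scaffold

This account rests on a few compounds, and the source may have more. Where it says the series, first, only, none or still open, it means among the compounds named here.

Compound 1 `COc1ccc(-c2ccc3c(c2)C(=O)C(=O)N3)cc1` is the stronger of the two measured compounds: in a functional assay on HepG2 cells (Homo sapiens) for antiproliferative activity, read by MTT assay, with a stated time of 48 h (on this read-out higher numbers stand for weaker inhibition and lower numbers for stronger inhibition), compound 1 gives 960 nM, which is the lowest number here. Its nearest neighbour, compound 2 `COc1ccc(-c2ccc3c(c2)C(=O)C(=O)N3C)cc1`, carries a methyl on the amide-type nitrogen and gives 6670 nM in this assay, a clear weakening of a 6.9-fold higher number from compound 1 to compound 2 (0.84 log units; beyond the scatter).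

Compound 3 `COc1ccc(-c2ccc3c(c2)C(=O)C(=O)N3Cc2ccccc2Cl)cc1` differs from compound 1 by 2-chlorobenzyl in place of hydrogen on an amide-type nitrogen in a ring. Among the measured compounds shown here, the only measured step that bears on this change is the one from compound 1 to compound 2, where replacing the hydrogen on the same nitrogen with a methyl cost a 6.9-fold higher number from compound 1 to compound 2 (0.84 log units; beyond the scatter). A 2-chlorobenzyl is a much larger group than a methyl, so how far that loss carries over is uncertain; a weakening beyond the scatter, though not necessarily as large, seems the more likely outcome. Compound 3 is therefore expected to be weaker than compound 1 in this assay, by roughly a 3.1-fold higher number from compound 1 to compound 3 (0.49 log units; beyond the scatter), with an estimated value of 3000 nM in the range 700 nM to 15000 nM.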

Compound 3, half-maximal inhibitory concentration: 600 nM
Compound 3: the middle estimate sits 5.0-fold (0.70 log units) above what was measured, outside the stated range (below it).
By their numbers in this assay, from the lowest: compounds 3 and 1 (each within the scatter of the next); then compound 2.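

The ring nitrogen need not keep its hydrogen to hold this level of activity: in this assay, 2-chlorobenzyl in place of that hydrogen gives a result within the scatter (a 1.6-fold lower number from compound 1 to compound 3 (0.20 log units; within the scatter)), so compound 1 and compound 3 cannot be told apart. The loss seen with methyl therefore does not extend to every group on this nitrogen, as adding 2-chlorophenyl to the saturated chain carbon of that methyl shows (an 11-fold lower number from compound 2 to compound 3 (1.05 log units; beyond the scatter)). Nothing available explains why these two groups behave so differently.

As far as these compounds go, whether the chlorine contributes remains open, as a plain benzyl on this nitrogen would be needed to tell. From the compounds shown here alone, it is also open whether a longer alkyl chain or an amine-bearing chain here would follow methyl or 2-chlorobenzyl.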